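Replacing the Chlorophenyl Arm: An Untested Thiophene Variant

The compounds below may be only part of what the source reports. "The series", "measured", "known", "first", "only" and "open" are said of these compounds alone.

Of the compounds shown here, three built on one shared core have been measured in a functional assay on cells for antagonist activity at prostaglandin E2 receptor EP1 subtype (Rattus norvegicus), read by fluorescence and calcium flux, with a stated time of 60 s; a lower number here means a stronger inhibitor, a higher number a weaker inhibitor. Compound 1 `O=C(O)c1cccc(Cc2c(-c3ccccc3)nn3cc(F)ccc23)n1` gives 380 nM. Within the data shown here, compound 2 `CSc1ccc2c(Cc3cccc(C(=O)O)n3)c(-c3ccccc3)nn2c1` gives 87 nM, and the single change between them, a 4.4-fold lower number from compound 1 to compound 2 (0.64 log units; beyond the scatter), sits on the fused ring rather than on the pendant aryl group. Compound 3 `O=C(O)c1cccc(Cc2c(-c3cccc(Cl)c3)nn3cc(Cl)ccc23)n1` gives 480 nM, the highest of the three numbers; its gap to compound 1 lies within the scatter, while compound 2 stands beyond the scatter from it, so compound 3 cannot be called the weakest of the set with any confidence.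

Compound 4 `O=C(O)c1cccc(Cc2c(-c3cccs3)nn3cc(Cl)ccc23)n1` differs from compound 3 in one place: thiophen-2-yl in place of 3-chlorophenyl on an aromatic carbon. Among the measured compounds shown here, no measured step touches this position. For the measured compounds named here, the only single-point step in the set, from compound 1 to compound 2, concerns the fused ring, and compound 1 and compound 3 differ in two places at once, with numbers that sit within the scatter of each other. Nothing in the data therefore points to a direction for this assay here, and the expectation is a change no larger than the scatter: compound 4 is expected to show a 1.2-fold lower number from compound 3 to compound 4 (0.08 log units; within the scatter). Compound 4 is accordingly estimated at 400 nM, with a range from 150 nM to 1200 nM.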

Compound 4, half-maximal inhibitory concentration: 1100 nM
For compound 4 the middle estimate is 2.8-fold (0.44 log units) below the measured one; measured number inside the range.
By their numbers in this assay, from the lowest: compound 2; then compounds 1 and 3 (each within the scatter of the next); then compound 4.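

In this assay, among these compounds, the exchange on this aromatic carbon of the five-membered aromatic ring with 2 nitrogen gives a 2.3-fold higher number from compound 3 to compound 4 (0.36 log units; beyond the scatter), which shows that a position no earlier single-point step had touched does respond to the group it carries. Among the compounds shown here, the change is modest, but it runs the opposite way to the only earlier step, a 4.4-fold lower number from compound 1 to compound 2 (0.64 log units; beyond the scatter), which lay on the fused ring, so thiophen-2-yl serves the inhibitor less well here than 3-chlorophenyl does. Nothing available on these compounds gives a reason for the shift.

A single step cannot tell whether the higher number follows from the five-membered ring entering or from the chlorine leaving with the 3-chlorophenyl group, and a thiophen-3-yl or a furan-2-yl on the same carbon would bear on that question. On these data alone, it also remains open whether a methylsulfanyl group on the fused ring, which went with the lower number in the earlier step, would have the same effect alongside thiophen-2-yl.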